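Thiazolyl amide expected close to the anilide value

This account rests on a few compounds, and the source may have more. Where it says the series, first, only, none or still open, it means among the compounds named here.

In a functional assay on the whole organism for inhibition, with Rattus norvegicus as the target, read by cytopathic effect and paw edema, at a dose of 100 mg/kg by the oral route (on this read-out higher numbers stand for more inhibition at the one dose given (going by the name of the read-out) and lower numbers for less inhibition), compound 1 `CCOC(=O)c1c(O)c2cccnc2n(-c2ccccc2)c1=O` gives 15.5%, compound 2 `Cc1cccc(NC(=O)c2c(O)c3cccnc3n(-c3ccccc3)c2=O)c1` gives 4.5%, and compound 3 `Cc1ccccc1NC(=O)c1c(O)c2cccnc2n(-c2ccccc2)c1=O` gives 9.8%. On the bare numbers compound 3 stands second of the three, yet it lies within the scatter of both compound 1 and compound 2, so no ranking among them can be read. Compound 4 `O=C(Nc1nccs1)c1c(O)c2cccnc2n(-c2ccccc2)c1=O` differs from compound 3 as follows: 1,3-thiazol-2-yl in place of 2-methylphenyl on an amide-type nitrogen. Among the compounds with values here, the one swap on the amide-type nitrogen, a number 5.3 percentage points higher from compound 2 to compound 3 (within the scatter), stayed within the scatter, and the steps from the ester, a number 11 percentage points lower from compound 1 to compound 2 (beyond the scatter) and a number 5.7 percentage points lower from compound 1 to compound 3 (within the scatter), were modest at most. Within the data shown here, no measured compound carries the thiazolyl group. A step of a number 0.8 percentage points lower from compound 3 to compound 4 (within the scatter) is therefore expected, none beyond the scatter. Compound 4 is estimated at 9%, between 0% and 24%.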

Compound 4, a percentage reported as inhibition, in the whole organism at one dose (the size of the read-out at that dose, not a potency): 2.5%
Estimate against measurement, compound 4: 6.5 percentage points above, and the stated range covers the measured number.
By their numbers in this assay, from the lowest: compounds 4, 2, 3 and 1 (each within the scatter of the next, the first and the last beyond it).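

In this assay, 1,3-thiazol-2-yl on the amide-type nitrogen gives a number 7.3 percentage points lower from compound 3 to compound 4 (within the scatter) and a number 2 percentage points lower from compound 2 to compound 4 (within the scatter) so the five-membered aromatic ring with 2 hetero atoms cannot be told apart from either methylphenyl group. Only the change on the carbonyl carbon, a number 13 percentage points lower from compound 1 to compound 4 (beyond the scatter) stands clear, and it remains modest. Nothing measured here offers a reason for these numbers. Open, from the compounds shown here alone, is whether a benzyl or cyclohexyl group on the amide-type nitrogen would give a number beyond the scatter of these amides. Also open, going by these compounds, is how a carboxylic acid on the carbonyl carbon would read.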